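This account rests on a few compounds, and the source may have more. Where it says the series, first, only, none or still open, it means among the compounds named here.

Working notes on the series. In a functional assay (brain) with Canis familiaris (Canis lupus familiaris) as the target (on this read-out higher numbers stand for weaker inhibition and lower numbers for stronger inhibition), compound 1 (`COC(CNc1ccccc1)CN1CCN(CCCC(c2ccc(F)cc2)c2ccc(F)cc2)CC1`) gives 15000 nM and compound 2 (`CC(=O)OC(CSc1ccccc1)CN1CCN(CCCC(c2ccc(F)cc2)c2ccc(F)cc2)CC1`) gives 20000 nM. These two values lie within the scatter of each other, so compound 2 stands level with compound 1 and the pair cannot be ranked.

Compound 3 (`CC(=O)OC(CNc1ccccc1)CN1CCN(CCCC(c2ccc(F)cc2)c2ccc(F)cc2)CC1`) comes from compound 2 through anilino in place of phenylsulfanyl on a saturated chain carbon, two bonds along the chain from an oxygen next to a carbonyl group.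

For the measured compounds named here, no measured pair isolates this exchange, so its size in this assay has no direct precedent. Going by the values given here, the only indirect guide is compound 1, which also carries the anilino group and gives 15000 nM, within the scatter of compound 2. On that basis no step beyond the scatter is expected, and no direction can be favoured with confidence. The expected change is a 1.3-fold lower number from compound 2 to compound 3 (0.10 log units; within the scatter), a small one.

For compound 3 the estimated value is 16000 nM, with an expected range of 6000 nM to 40000 nM.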

Compound 3, half-maximal inhibitory concentration: 13000 nM
For compound 3 the middle estimate is 1.2-fold (0.09 log units) above the measured one; the measured number falls inside the stated range.
By their numbers in this assay, from the lowest: compounds 3, 1 and 2 (each within the scatter of the next).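

In this assay the exchange of phenylsulfanyl for anilino on a saturated chain carbon, two bonds along the chain from an oxygen next to a carbonyl group, now has a direct reading: a 1.5-fold lower number from compound 2 to compound 3 (0.19 log units; within the scatter) is what the pair shows, so the two groups cannot be told apart here, although anilino brings 1 hydrogen-bond donor where phenylsulfanyl has 0. The second exchange, acetyl in place of methyl on an oxygen on a saturated carbon, gives a 1.2-fold lower number from compound 1 to compound 3 (0.06 log units; within the scatter) and likewise leaves the two compounds level, so at the present level of precision neither position has yet produced a separable difference in this series. No accompanying measurement bears on what lies behind these readings.

From the compounds shown here alone, whether a phenoxy or benzylamino group in place of anilino, or a free hydroxyl in place of the acetyl ester, would produce a step beyond the scatter remains open. Going by these compounds, all three compounds carry the shared core unchanged, so the contribution of that core to the values in this assay also remains open.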